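The source may report more compounds than this note shows. Statements on the series, on what has been measured and on what is new or still open speak of the compounds shown alone.

Series notes on the acetoxy aromatics with a long unsaturated chain.

Compound 1 `CCCCCC/C=C\CCCCCCCc1cccc(OC(C)=O)c1` is the reference. In an assay for inhibition of 1-phosphatidylinositol 4,5-bisphosphate phosphodiesterase gamma-1 (Bos taurus) (a lower number here means a stronger inhibitor, a higher number a weaker inhibitor), compound 1 returns only the limit of the assay, > 250 ug/mL, not a number. Compound 2 `CCCCCC/C=C\CCCCCCCc1cc(OC(C)=O)cc(OC(C)=O)c1` carries a second acetoxy group in place of a hydrogen on the shared core. In this assay compound 2 likewise gives only the limit, > 250 ug/mL. The step from one to the other, a step that the two limits leave unreadable from compound 1 to compound 2, is therefore not readable in either direction, and the whole measured picture of the series is that both values sit at the same limit (the limit of > 250 ug/mL in this assay, at which 2 of the 2 values shown sit).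

Compound 3 `CCCCCC/C=C\CCCCCCCc1cccc(OC(C)=O)c1C(=O)OC` is the next unmeasured member. It differs from compound 1 by methoxycarbonyl in place of hydrogen on an aromatic carbon. No measured step in this assay is readable, so nothing shown supports a change in any direction for this substitution, and no step beyond the scatter can be expected from the shown data. The expected step from compound 1 to compound 3 in this assay is thus a number no higher from compound 1 to compound 3 (the limit leaves the size open). For compound 3 in this assay the estimate is 250 ug/mL, ranging from 100 ug/mL to 1000 ug/mL, most probably reported again as a limit.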

Compound 3, half-maximal inhibitory concentration: > 250 ug/mL
Compound 3: a limit, no number; the forecaster's own chance of this, stated with the estimate: 75%; the middle value sits exactly at the limit.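

In this assay, going by these compounds alone, compound 3 gives > 250 ug/mL as a limit and not a number, so no step between compound 1 and compound 3 can be read. The compounds shown leave open where any member of the series stands as an actual number, and whether a second acetoxy or a methoxycarbonyl on the shared core changes it at all.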